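This account rests on a few compounds, and the source may have more. Where it says the series, first, only, none or still open, it means among the compounds named here.

Compound 1 `CCCC(=O)CC/C=C/C=C/C#CC#C/C=C/COC(=O)CCl`: 12600 nM
Compound 2 `CCCC(=O)CC/C=C/C=C/C#CC#C/C=C/C=O`: > 30000 nM

Both compounds were tested in a functional assay on 518A2 cells (Homo sapiens) for cytotoxicity, read by sulforhodamine B assay, with a stated time of 96 h; on this read-out higher numbers stand for an effect only at larger amounts of compound and lower numbers for an effect already at smaller amounts. Compound 2 stands at the limit of > 30000 nM in this assay, at which 1 of the 2 values shown sits, and that figure is a limit, not a number. Compound 3 `CCCC(=O)CC/C=C/C=C/C#CC#C/C=C/C(=O)O` differs from compound 2 by a single change, hydroxy in place of hydrogen on a carbonyl carbon, which turns formyl into carboxy. For the measured compounds named here, only one measured step bears on this, an at least 2.3-fold higher number from compound 1 to compound 2 (0.37 log units; beyond the scatter). As far as these compounds go, that step created the formyl group now being altered, and its full size is unknown since it ends at a limit. It offers no sign that a change to this group would recover activity, so no step beyond the scatter is expected in this assay. The expected step is a step that the limit leaves unreadable from compound 2 to compound 3. For compound 3 the estimated value is 40000 nM, with an expected range from 15000 nM to 100000 nM.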

Compound 3, half-maximal effective concentration: > 30000 nM
Compound 3: only a limit was reported; the forecaster's own chance of this, stated with the estimate: 75%; the middle value lies beyond the limit too.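

In this assay, hydroxy in place of hydrogen on the carbonyl carbon leaves compound 3 at the same limit as compound 2, and the step between them cannot be read: the limit of > 30000 nM in this assay, at which 2 of the 3 values shown sit.

What compound 3 adds is a second replacement at this position, with carboxy in place of (((chloromethyl)carbonyl)oxy)methyl giving an at least 2.3-fold higher number from compound 1 to compound 3 (0.37 log units; beyond the scatter). Neither formyl nor carboxy on this double-bonded chain carbon therefore retains a readable value, and turning formyl into carboxy brings none back.

As far as these compounds go, how far compound 2 and compound 3 each lie past the limit stays unknown, and no order can be given between them. Also open, from the compounds shown here alone, is whether hydroxymethyl, acetoxymethyl or an aminomethyl group in this place would return a readable value like that of compound 1.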